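Removing the Nitro Group from an Oxime Anilide

The source may report more compounds than this note shows. Statements on the series, on what has been measured and on what is new or still open speak of the compounds shown alone.

Measured compounds:
compound 1, `N#C/C(=N\O)C(=O)Nc1cccc(C(F)(F)F)c1`, 4.88
compound 2, `N#C/C(=N\O)C(=O)Nc1ccc(F)cc1`, 5.01
compound 3, `N#C/C(=N\O)C(=O)Nc1ccc([N+](=O)[O-])cc1`, 4.61

In a physicochemical assay for acid dissociation, using potentiometric titration, compound 3 gives the lowest of the three numbers, but the gap to compound 1 lies within the usual scatter; only compound 2 stands clearly higher. Among the measured compounds shown here, the one step that bears on the question runs a number 0.40 log units lower from compound 2 to compound 3 (beyond the scatter), in this assay.

Compound 4, `N#C/C(=N\O)C(=O)Nc1ccccc1`, is reached from compound 3 by one change: hydrogen in place of nitro on an aromatic carbon. This change runs in the opposite sense to the change from compound 2 to compound 3, in that the nitro group is now taken away rather than put in. For the measured compounds named here, it is expected, then, that the number for compound 4 moves back upward, by roughly the same amount as a number 0.40 log units lower from compound 2 to compound 3 (beyond the scatter) or slightly more, since compound 2 still carries fluoro where compound 4 carries hydrogen, and no measured pair shows what that exchange is worth. The estimated step is a number 0.54 log units higher from compound 3 to compound 4 (beyond the scatter). For compound 4 the estimate in this assay is 5.15, expected to fall between 4.9 and 5.4.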

Compound 4, acid dissociation constant: 5.12
Estimate against measurement, compound 4: 0.03 log units above, and the stated range covers the measured number.
By their numbers in this assay, from the lowest: compounds 3, 1, 2 and 4 (each within the scatter of the next, the first and the last beyond it).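

In this assay, hydrogen in place of nitro gives a number 0.51 log units higher from compound 3 to compound 4 (beyond the scatter) on this aromatic carbon, para to a group of 8 heavy atoms. Among the compounds shown here, with this step, the nitro compound is now set apart beyond the scatter from both its hydrogen and its fluoro counterparts, whereas the earlier compounds showed only the comparison with fluoro. Hydrogen in place of fluoro gives a number 0.11 log units higher from compound 2 to compound 4 (within the scatter) and so cannot be told from fluoro here, while hydrogen in place of trifluoromethyl gives a number 0.24 log units higher from compound 1 to compound 4 (within the scatter) and likewise stays inside the scatter, and nothing at hand gives a measured reason for the size of any of these steps.

The compounds shown leave open how this number responds when the same aromatic carbon carries an amine, a carboxylic acid or a methoxy group, none of which stands among them. They also leave open whether nitro on another carbon of the ring, or two such groups on the ring together, would give a step of similar size, and the four values alone cannot settle this.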